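Swapping the methyl for a hydroxyl on the phenyl ring

A few compounds are considered here, and "the series" means these few. Any claim that something is new, unique, unknown or untested is made for them only; others in the source may bear on it.

Compound 1 `Cc1nc(-c2cccnc2)sc1-c1nnc(-c2ccc([N+](=O)[O-])cc2)o1`: in an ADME assay on HeLa cells (Homo sapiens) for cytotoxicity, read by MTT assay (on this read-out higher numbers stand for lower toxicity in this test and lower numbers for higher toxicity in this test), compound 1 gives > 100 ug/mL, which is a limit of the test rather than a number.
Compound 2 `Cc1nc(-c2cccnc2)sc1-c1nnc(-c2ccc(Cl)cc2)o1`: in this assay compound 2 gives > 100 ug/mL, also a limit.
Compound 3 `Cc1ccccc1-c1nnc(-c2sc(-c3cccnc3)nc2C)o1`: in this assay compound 3 gives > 100 ug/mL, again a limit.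

Compound 3 therefore stands where every measured compound stands: at the top limit of the cell test, with no number to compare. The two steps between the measured compounds, a step that the two limits leave unreadable from compound 1 to compound 2 and a step that the two limits leave unreadable from compound 2 to compound 3, each exchange the substituent on the phenyl ring that hangs from the shared core, and both end at the same limit, so their size cannot be read.

The step considered here is 4-hydroxyphenyl in place of 2-methylphenyl on an aromatic carbon, giving compound 4 `Cc1nc(-c2cccnc2)sc1-c1nnc(-c2ccc(O)cc2)o1`. The measured steps bear on it only loosely: they show that two earlier exchanges at this same phenyl ring left the value at the limit, but they cannot say how large a step is. Because the limit of > 100 ug/mL in this assay, at which 3 of the 3 values shown sit, holds for every compound in the set, no step beyond the scatter is expected in this assay, in either direction.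

Compound 4 is therefore expected to give about 150 ug/mL, within a range of 60 ug/mL to 400 ug/mL. The expected step is a step that the limit leaves unreadable from compound 3 to compound 4, most likely reported once more as a limit rather than a number.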

Compound 4, half-maximal cytotoxic concentration: > 100 ug/mL
Compound 4: only a limit was reported; the forecaster's own chance of this, stated with the estimate: 85%; the middle value does not contradict the limit.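

In this assay compound 4 gives > 100 ug/mL, which is a limit and not a number. No step can be read between compound 4 and compound 1, compound 2 or compound 3, because all four share one limit: the limit of > 100 ug/mL in this assay, at which 4 of the 4 values shown sit. The compounds shown leave open how far any exchange on this phenyl ring changes the true value, and which group, if any, would give a readable number.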